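Swapping cyano for methoxy: what to expect

The compounds below may be only part of what the source reports. "The series", "measured", "known", "first", "only" and "open" are said of these compounds alone.

Compound 1 `N#Cc1ccc(CN[C@H]2[C@@H]3CN(c4ncc(C(=O)NO)cn4)C[C@@H]32)cc1` with 270 nM
Compound 2 `O=C(NO)c1cnc(N2C[C@@H]3[C@H](C2)[C@H]3NCc2ccc(OC(F)(F)F)cc2)nc1` with 120 nM

Among the measured compounds shown here, in a functional assay on HCT-116 cells (Homo sapiens) for antiproliferative activity, read by WST assay, with a stated time of 72 h (on this read-out higher numbers stand for weaker inhibition of growth and lower numbers for stronger inhibition of growth), compound 1 gives 270 nM and holds the higher of the two numbers so far, which makes it the weaker growth inhibitor of the pair. Still unmeasured is compound 3 `COc1ccc(CN[C@H]2[C@@H]3CN(c4ncc(C(=O)NO)cn4)C[C@@H]32)cc1` which keeps the core of compound 1 and carries methoxy in place of cyano on an aromatic carbon, para to a large group (methoxy in place of cyano on an aromatic carbon). For the measured compounds named here, only one measured step bears on this change: a 2.3-fold lower number from compound 1 to compound 2 (0.35 log units; beyond the scatter) with trifluoromethoxy in place of cyano on an aromatic carbon. Going by the values given here, that step is modest and stands alone, and no methoxy compound has been measured yet. In this assay a lower number is therefore expected, of similar or smaller size, possibly within the scatter. The expected change is a 1.6-fold lower number from compound 1 to compound 3 (0.20 log units; within the scatter) in this estimate. Compound 3 is estimated at 170 nM (expected range 85 nM to 330 nM).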

Compound 3, concentration for 50% growth inhibition: 190 nM
For compound 3 the middle estimate is 1.1-fold (0.05 log units) below the measured one; the range from low to high includes it.
By their numbers in this assay, from the lowest: compounds 2, 3 and 1 (each within the scatter of the next, the first and the last beyond it).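

In this assay, methoxy in place of cyano on this aromatic carbon gives a 1.4-fold lower number from compound 1 to compound 3 (0.15 log units; within the scatter) and so cannot be told apart from the usual variation between repeat measurements. Methyl in place of trifluoromethyl on the oxygen gives a 1.6-fold higher number from compound 2 to compound 3 (0.20 log units; within the scatter) and is just as unresolved, so compound 3 cannot be ranked against either compound 1 or compound 2, even though those two differ from each other beyond the scatter. No measurement shown here offers an explanation for these differences.

Going by these compounds, it remains open whether an amine or a carboxylic acid at this position would shift the number beyond the scatter. A longer chain on the oxygen, such as ethoxy or propoxy, leaves the same question unanswered.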